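Cyclobutyl replaces 1-methyl-1H-pyrrol-3-yl at an assay limit

The source may report more compounds than this note shows. Statements on the series, on what has been measured and on what is new or still open speak of the compounds shown alone.

In an ADME assay on Huh-7 cells (Homo sapiens) for cytotoxicity, with a stated time of 72 h (a lower number here means that less compound is tolerated, a higher number that more compound is tolerated), compound 1 (`CC(C)CCn1nc(-c2cccs2)c(O)c(C2=NS(=O)(=O)c3cc(NS(=O)(=O)C4CC4)ccc3N2)c1=O`) gives > 1000 nM as a limit and not a number. Compound 2 (`CS(=O)(=O)Nc1ccc2c(c1)S(=O)(=O)N=C(c1c(O)c(-c3ccsc3)nn(CCC3CC3)c1=O)N2`) gives > 1000 nM as a limit too. Compound 3 (`CC(C)CCn1nc(-c2ccn(C)c2)c(O)c(C2=NS(=O)(=O)c3cc(NS(C)(=O)=O)ccc3N2)c1=O`) gives > 1000 nM as a limit as well. All three therefore stand together (the limit of > 1000 nM in this assay, at which 3 of the 3 values shown sit) and compound 3 has no number that could rank it against the other two.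

Compound 4 (`CC(C)CCn1nc(C2CCC2)c(O)c(C2=NS(=O)(=O)c3cc(NS(C)(=O)=O)ccc3N2)c1=O`) differs from compound 3 by cyclobutyl in place of 1-methyl-1H-pyrrol-3-yl on an aromatic carbon, next to the ring nitrogen and ortho to a hydroxy group (cyclobutyl in place of 1-methyl-1H-pyrrol-3-yl on an aromatic carbon) while the rest of the structure stays the same. For the measured compounds named here, no pair of measured compounds differs in one place only, so the data put no size on such a change.

The expectation in this assay is a step within the scatter, in neither direction, resting on compound 3 at > 1000 nM as a limit. The expected change is a step that the limit leaves unreadable from compound 3 to compound 4 in this estimate. For compound 4 the estimated half-maximal cytotoxic concentration is 2000 nM with an expected range from 1000 nM to 10000 nM and a report as a limit alone is the likelier outcome.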

Compound 4, half-maximal cytotoxic concentration: > 33000 nM
Compound 4: only a limit was reported; the forecaster's own chance of this, stated with the estimate: 85%; at least 16-fold (1.21 log units) between middle value and limit.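

In this assay compound 3 gives > 1000 nM, a limit and not a number. For the compounds shown here, compound 4 gives > 33000 nM, again a limit, so no step between compound 3 and compound 4 can be read. The compounds shown leave open whether cyclobutyl in place of 1-methyl-1H-pyrrol-3-yl changes the half-maximal cytotoxic concentration at all, and by how much.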